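Replacing 4-methoxyphenyl with 3-nitrophenyl in compound 3

The compounds below may be only part of what the source reports. "The series", "measured", "known", "first", "only" and "open" are said of these compounds alone.

In a functional assay on K562 cells (Homo sapiens) for cytotoxicity, read by sulforhodamine B assay (on this read-out lower numbers stand for stronger inhibition of growth and higher numbers for weaker inhibition of growth), compound 1 `CC1=CC[C@@H]([C@@](C)(O)CCCC(C)(C)NC=S)CC1` gives only a limit, > 100000 nM, and no number. Compound 2 `CC1=CC[C@@H]([C@@](C)(O)CCCC(C)(C)NC(=S)N/N=C\c2ccc(C)cc2)CC1` gives 7950 nM. Compound 3 `COc1ccc(/C=N\NC(=S)NC(C)(C)CCC[C@](C)(O)[C@@H]2CC=C(C)CC2)cc1` gives 34900 nM, the higher of the two actual numbers, which makes it the weaker growth inhibitor of that pair. Among the compounds with values here, the single measured step between compounds that differ in one place is a 4.4-fold higher number from compound 2 to compound 3 (0.64 log units; beyond the scatter), and it puts methoxy in place of methyl on an aromatic carbon.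

Compound 4 `CC1=CC[C@@H]([C@@](C)(O)CCCC(C)(C)NC(=S)N/N=C\c2cccc([N+](=O)[O-])c2)CC1` has not yet been measured in this assay. It carries 3-nitrophenyl in place of 4-methoxyphenyl on a carbon with a double bond to nitrogen. Within the data shown here, only one measured step bears on this change, and the methoxy group that it introduced now leaves again. That step, a 4.4-fold higher number from compound 2 to compound 3 (0.64 log units; beyond the scatter), was modest and went toward a higher number, so some recovery toward a lower number seems likely. Among the measured compounds shown here, no measured compound carries a nitro group, however, which keeps the expectation cautious and the range wide.

The expected change is a 2.3-fold lower number from compound 3 to compound 4 (0.37 log units; beyond the scatter), a modest step toward a lower number. For compound 4 the estimated value is 15000 nM, with an expected range from 4000 nM to 60000 nM.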

Compound 4, concentration for total growth inhibition: 560 nM
For compound 4 the middle estimate is 27-fold (1.43 log units) above the measured one; measured number below the stated range.
By their numbers in this assay, from the lowest: compound 4; then compound 2; then compound 3. At a limit, above all of these: compound 1.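

In this assay the aryl group on a carbon with a double bond to nitrogen proves able to move the read-out far more than the earlier pair showed, with a 62-fold lower number from compound 3 to compound 4 (1.79 log units; beyond the scatter) as a large step where the methyl-to-methoxy step, a 4.4-fold higher number from compound 2 to compound 3 (0.64 log units; beyond the scatter), was only modest. The 3-nitrophenyl group also improves on the 4-methylphenyl group, the better of the two earlier aryl groups, giving a 14-fold lower number from compound 2 to compound 4 (1.15 log units; beyond the scatter) and making compound 4 the strongest growth inhibitor among the compounds with actual numbers. No measurement shown here accounts for the size of this gain.

The step from compound 3 to compound 4 changes the substituent and its numbered ring position together, so the compounds shown cannot say how much of the gain belongs to the nitro group itself and how much to where it sits. They also leave open whether an amine or a carboxylic acid in place of the nitro group on the same phenyl ring would keep the lower number, and whether a bare phenyl ring would fall nearer compound 2 or compound 4.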